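Adding a methoxycarbonyl to compound 1: what to expect

The compounds below may be only part of what the source reports. "The series", "measured", "known", "first", "only" and "open" are said of these compounds alone.

compound 1 `c1ccc(-c2nc3cccnc3n2C2CCCC2)cc1` gives 3000 nM
compound 2 `Cc1cccc(-c2nc3cccnc3n2C2CCCC2)c1Cl` gives 646 nM
compound 3 `CN(C)c1cccc(-c2nc3cccnc3n2C2CCCC2)c1` gives 455 nM

These numbers come from a functional assay on MDA-MB-231 cells (Homo sapiens) for cytotoxicity, read by MTT assay, with a stated time of 24 h (a lower number here means a stronger inhibitor, a higher number a weaker inhibitor), and compound 1 has the highest of the three, which makes it the weakest inhibitor of the set. Compound 4 `COC(=O)c1ccc(-c2nc3cccnc3n2C2CCCC2)cc1` keeps the core of compound 1 and takes methoxycarbonyl in place of hydrogen on an aromatic carbon, para to a large group (methoxycarbonyl in place of hydrogen on an aromatic carbon). Among the measured compounds shown here, only one measured step changes a single place on compound 1, and it also replaces hydrogen on an aromatic carbon. That step is a 6.6-fold lower number from compound 1 to compound 3 (0.82 log units; beyond the scatter) as dimethylamino enters. For the measured compounds named here, compound 2 differs from compound 1 in more than one place, so it offers no clean step, although compound 2 at 646 nM also has a lower number than compound 1. Going by the values given here, neither compound goes against this direction, but two compounds are a thin base, and no methoxycarbonyl compound has a measured value yet. Among the compounds with values here, with compound 3 at 455 nM as the only clean guide, a lower number is expected, but a different group enters, so the drop may well be smaller. The estimated change is a 3.0-fold lower number from compound 1 to compound 4 (0.48 log units; beyond the scatter) and it remains uncertain. The estimate for compound 4 is 1000 nM as the expected value, with 350 nM to 2800 nM as the likely range.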

Compound 4, half-maximal inhibitory concentration: 350 nM
The estimate for compound 4 lay 2.9-fold (0.46 log units) above the measured number; the range from low to high includes it.
By their numbers in this assay, from the lowest: compounds 4, 3 and 2 (each within the scatter of the next); then compound 1.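

The place para to a large group on the carbon-only aromatic ring, which carries no substituent in compounds 1, 2 or 3, accepts methoxycarbonyl without any loss in this assay and in fact gives an 8.6-fold lower number from compound 1 to compound 4 (0.93 log units; beyond the scatter) as its reading. This is a second clean single-place change on the core of compound 1 that lowers the number, after a 6.6-fold lower number from compound 1 to compound 3 (0.82 log units; beyond the scatter) with dimethylamino, so two different groups replacing an aromatic hydrogen now point the same way, and no compound shown goes against that direction. Nothing measured here explains why the added group lowers the number, so the step stands as an observation only.

Two steps of this kind still cannot show whether the drop depends on methoxycarbonyl itself or would follow from almost any group placed on this ring. A carboxylic acid, a primary amide or a simple methyl at the same place, along with methoxycarbonyl on another carbon of the ring, would begin to separate the effect of the group from the effect of its place.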